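The source may report more compounds than this note shows. Statements on the series, on what has been measured and on what is new or still open speak of the compounds shown alone.

Of the compounds shown here, two built on a shared core have so far been measured in a functional assay on the whole organism for inhibition, with Mus musculus as the target; a higher number here means that more compound is needed for the effect, a lower number that less compound is needed. There, compound 1 `CN1Cc2c(N)cccc2C(c2ccc(F)cc2)C1` gives about 3.6 mg/kg and compound 2 `CCOC(=O)Nc1cccc2c1CN(C)CC2c1ccc(Cl)cc1` gives 4.8 mg/kg, and these two numbers lie within the usual scatter of each other. Compound 3 `CCOC(=O)Nc1cccc2c1CN(C)CC2c1ccc(F)cc1` has not yet been measured. It differs from compound 2 in one place only (fluoro in place of chloro on an aromatic carbon), with fluoro in place of chloro on an aromatic carbon, para to a large group, so that 4-chlorophenyl becomes 4-fluorophenyl.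

Going by the values given here, no measured pair shows this swap on its own, so there is no direct precedent for its size. The nearest hint is that compound 1 already carries a 4-fluorophenyl group and sits at about 3.6 mg/kg, although it also differs from compound 2 elsewhere in its structure. On this thin evidence, no step beyond the scatter is expected in this assay. The expected change is small, a 1.1-fold lower number from compound 2 to compound 3 (0.03 log units; within the scatter), with no firm direction. Compound 3 is estimated at 4.5 mg/kg, with 2.2 mg/kg to 9.5 mg/kg as the expected range.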

Compound 3, dose for half-maximal effect: 3.5 mg/kg
Compound 3: the middle estimate sits 1.3-fold (0.11 log units) above what was measured; the measured number falls inside the stated range.
By their numbers in this assay, from the lowest: compounds 3, 1 and 2 (each within the scatter of the next).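

In this assay the change from 4-chlorophenyl to 4-fluorophenyl reads as a 1.4-fold lower number from compound 2 to compound 3 (0.14 log units; within the scatter) and gives the first direct view of this swap on its own: at this place on the shared core, chloro and fluoro cannot be told apart in this test. The new compound also allows a second clean comparison, with the 4-fluorophenyl group held fixed, and ethoxycarbonyl in place of hydrogen on the nitrogen on the aromatic ring reads as a 1.0-fold lower number from compound 1 to compound 3 (0.01 log units; within the scatter) and so also leaves the dose needed within the scatter. Nothing available here accounts for how little either change does.

Each of these two changes rests on a single pair, so neither shows whether the same result would hold with the other group in place, such as chloro alongside the unsubstituted amine. Also open, on these data alone, is how this test would respond to a different group at these places, such as methoxy or trifluoromethyl on the phenyl ring, or a longer chain than ethyl in the ethoxycarbonyl group on the nitrogen.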